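Trifluoromethyl to Chloro: Estimating Compound 4

This account rests on a few compounds, and the source may have more. Where it says the series, first, only, none or still open, it means among the compounds named here.

Compound 1, `Cc1cc(=O)n(-c2ccccc2OC(F)(F)F)nc1C(=O)Nc1ccc(Oc2ncnc3c2ccn3C)cc1`, gives 25200 nM in a functional assay on A549 cells (Homo sapiens) for cytotoxicity, read by MTT assay, with a stated time of 72 h; a lower number here means a stronger inhibitor, a higher number a weaker inhibitor. Compound 2, `Cc1ccc(-n2nc(C(=O)Nc3ccc(Oc4ncnc5c4ccn5C)cc3)c(C)cc2=O)cc1`, reaches only a limit of this assay, > 60000 nM. Compound 3, `Cc1cc(=O)n(-c2ccccc2C(F)(F)F)nc1C(=O)Nc1ccc(Oc2ncnc3c2ccn3C)cc1`, gives 5860 nM in this assay.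

Compound 3 holds the lowest of the two numbers shown; the nearest is compound 1, with a 4.3-fold lower number from compound 1 to compound 3 (0.63 log units; beyond the scatter). Compound 4, `Cc1cc(=O)n(-c2ccccc2Cl)nc1C(=O)Nc1ccc(Oc2ncnc3c2ccn3C)cc1`, differs from compound 3 by chloro in place of trifluoromethyl on an aromatic carbon. Within the data shown here, two measured steps bear on this: a 4.3-fold lower number from compound 1 to compound 3 (0.63 log units; beyond the scatter), a change of group on the same carbon, and an at least 10-fold lower number from compound 2 to compound 3 (1.01 log units; beyond the scatter), which also moves the group. The change to compound 4 is expected to give a modest step, likely toward a higher number, a 1.5-fold higher number from compound 3 to compound 4 (0.19 log units; within the scatter). Compound 4 is therefore estimated at 9000 nM, within 3000 nM to 27000 nM.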

Compound 4, half-maximal inhibitory concentration: 5120 nM
Compound 4: the middle estimate sits 1.8-fold (0.24 log units) above what was measured; the measured number falls inside the stated range.
By their numbers in this assay, from the lowest: compounds 4 and 3 (each within the scatter of the next); then compound 1. At a limit, above all of these: compound 2.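

Trifluoromethyl gives way to chloro, a group of one heavy atom, with a 1.1-fold lower number from compound 3 to compound 4 (0.06 log units; within the scatter), so this place on the ring accepts a far smaller group without a change beyond the scatter. The 2-chlorophenyl group of compound 4 also reads lower than the other two aryl groups, with a 4.9-fold lower number from compound 1 to compound 4 (0.69 log units; beyond the scatter) and an at least 11-fold lower number from compound 2 to compound 4 (1.06 log units; beyond the scatter). Compound 2 stands at a limit of this assay, not at a number: the limit of > 60000 nM in this assay, at which 1 of the 4 values shown sits.

Going by these compounds, whether an amine or a carboxylic acid on this same carbon would read like compound 3 and compound 4 stays open. So does whether chloro would hold its number on a different carbon of the ring.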